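The source may report more compounds than this note shows. Statements on the series, on what has been measured and on what is new or still open speak of the compounds shown alone.

Measured so far:
- compound 1, `CN(C)c1ccccc1N1CCN(CCCCn2ncc(=O)n(C)c2=O)CC1`, 350 nM
- compound 2, `CSc1ccccc1N1CCN(CCCCn2ncc(=O)n(C)c2=O)CC1`, 1.8 nM
- compound 3, `Cn1c(=O)cnn(CCCCN2CCN(c3c(Br)cccc3C#N)CC2)c1=O`, 450 nM

All three share one core and differ only in the aromatic group attached to the ring nitrogen. In an assay for displacement of a labelled ligand from Adrenergic receptor alpha-1 (Homo sapiens) (a higher number here means a weaker inhibitor, a lower number a stronger inhibitor), compound 2 has the lowest number of the three: the nearest is compound 1, with a 250-fold higher number from compound 2 to compound 3 (2.40 log units; beyond the scatter) the furthest. Both steps are large, so among these three compound 2 is the strongest.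

Compound 4, `Cn1c(=O)cnn(CCCCN2CCN(c3cccc(Br)n3)CC2)c1=O`, has not yet been measured. Its change from compound 2 is 6-bromopyridin-2-yl in place of 2-(methylsulfanyl)phenyl on an amine nitrogen in a ring.

Within the data shown here, two measured steps bear on this. The change a 190-fold lower number from compound 1 to compound 2 (2.29 log units; beyond the scatter) shows how much depends on the methylsulfanyl group, and a 250-fold higher number from compound 2 to compound 3 (2.40 log units; beyond the scatter) shows that a different substituted ring in this place loses almost all of that advantage. Compound 4 again gives up the methylsulfanyl group and brings in a halogen-bearing ring, closer in kind to compound 3 than to compound 2. Among the measured compounds shown here, a large rise in the number is therefore expected, although no measured compound carries a nitrogen-containing ring here, so the size is uncertain.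

Compound 4 is estimated at 200 nM, within 20 nM to 2000 nM, an expected step of a 110-fold higher number from compound 2 to compound 4 (2.05 log units; beyond the scatter).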

Compound 4, inhibition constant: > 10000 nM
Compound 4 was reported as a limit; the forecaster's own chance of this, stated with the estimate: 5%; at least 50-fold (1.69 log units) between middle value and limit.
By their numbers in this assay, from the lowest: compound 2; then compounds 1 and 3 (each within the scatter of the next). At a limit, above all of these: compound 4.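

Compound 4 is reported only as a limit in this assay, not as an exact number: the limit of > 10000 nM in this assay, at which 1 of the 4 values shown sits.

Even so, the steps are large: an at least 5500-fold higher number from compound 2 to compound 4 (3.74 log units; beyond the scatter), an at least 22-fold higher number from compound 3 to compound 4 (1.34 log units; beyond the scatter) and an at least 28-fold higher number from compound 1 to compound 4 (1.45 log units; beyond the scatter). Compound 1 and compound 3 therefore did not mark the bottom of what a change on this amine nitrogen can cost, since compound 4 lies beyond both. Compound 4 is also the only compound shown with a hetero atom in this aromatic ring, yet its group has the same count of hydrogen-bond acceptors as 2-(methylsulfanyl)phenyl and no net charge, so those counts alone do not track the result.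

This change replaces the ring and its substituent together, so the compounds shown cannot say whether the loss follows the ring nitrogen, the bromine or the absence of methylsulfanyl. A 2-bromophenyl group, an unsubstituted pyridin-2-yl group and a 6-(methylsulfanyl)pyridin-2-yl group would each separate these parts, and a compound with a measurable value would be needed to size the effect.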